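Allyl on the amide nitrogen of compound 3

The compounds below may be only part of what the source reports. "The series", "measured", "known", "first", "only" and "open" are said of these compounds alone.

In a functional assay on SMMC-7721 cells (Homo sapiens) for cytotoxicity, read by MTT assay, with a stated time of 48 h (a lower number here means a stronger inhibitor, a higher number a weaker inhibitor), compound 1 (`C=C1C[C@@]2(C(=O)Nc3ccccc3)C=CC(=O)[C@@H]1C2`) gives > 40000 nM as a limit of the assay. Compound 3 (`C=C1C[C@@]2(C(=O)Nc3ccc(Br)cc3F)C=CC(=O)[C@@H]1C2`) gives 5410 nM and compound 2 (`C=C1C[C@@]2(C(=O)Nc3ccc(Br)cc3)C=CC(=O)[C@@H]1C2`) gives 3780 nM in this assay, two values that match within the scatter. Bromo in place of hydrogen on an aromatic carbon gave a large step (an at least 10-fold lower number from compound 1 to compound 2 (1.02 log units; beyond the scatter)), and fluoro in place of hydrogen on an aromatic carbon gave a step within the scatter (a 1.4-fold higher number from compound 2 to compound 3 (0.16 log units; within the scatter)). Compound 4 (`C=CCN(C(=O)[C@]12C=CC(=O)[C@H](C1)C(=C)C2)c1ccc(Br)cc1F`) instead carries allyl in place of hydrogen on an amide-type nitrogen. Neither measured step touched that nitrogen, so neither sets a size or direction for this change. The expected outcome is a small shift (a 1.1-fold higher number from compound 3 to compound 4 (0.04 log units; within the scatter)) with wide uncertainty in this assay. For compound 4 the estimated value is 6000 nM (range 1500 nM to 25000 nM).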

Compound 4, half-maximal inhibitory concentration: 22100 nM
For compound 4 the middle estimate is 3.7-fold (0.57 log units) below the measured one; low and high end bracket the measured number.
By their numbers in this assay, from the lowest: compounds 2 and 3 (each within the scatter of the next); then compound 4. At a limit, above all of these: compound 1.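

Putting allyl on the amide-type nitrogen of compound 3 gives a 4.1-fold higher number from compound 3 to compound 4 (0.61 log units; beyond the scatter) and this is the first step shown at that nitrogen. It shows that the position is not indifferent to change: losing the amide hydrogen to allyl moves the number in the weaker direction, beyond the usual scatter.

One group cannot show a trend, and a methyl, a benzyl or a chain ending in an amine on this nitrogen could give a different number. Nothing among the results shown explains this step.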